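Swapping one methoxy group for hydrogen: a half-life estimate

This account rests on a few compounds, and the source may have more. Where it says the series, first, only, none or still open, it means among the compounds named here.

Measured so far in an ADME assay, at pH 3; a lower number here means that the compound disappears faster, a higher number that the compound lasts longer:
- compound 1 `COc1ccnc(C[S+]([O-])c2nc3cc(OC(F)(F)C(F)F)ccc3[nH]2)c1OC` gives 0.3 h as its half-life
- compound 2 `COc1cnc(C[S+]([O-])c2nc3cc(OC(F)(F)C(F)F)ccc3[nH]2)cc1OC` gives 0.317 h as its half-life

These two numbers lie within the scatter of each other, so compound 2 holds no distinct place beside compound 1. Compound 3 `COc1ccnc(C[S+]([O-])c2nc3cc(OC(F)(F)C(F)F)ccc3[nH]2)c1` follows from compound 2 through hydrogen in place of methoxy on an aromatic carbon. Among the measured compounds shown here, no measured pair shows this single change, so the data offer no direct guide. Only a small downward step is expected in this assay, one that may not clear the scatter. The estimate amounts to a 1.4-fold lower number from compound 2 to compound 3 (0.16 log units; within the scatter) and would stay within the scatter. Compound 3 is estimated at 0.22 h in this assay, with 0.1 h to 0.5 h as its expected range.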

Compound 3, half-life: 0.167 h
The estimate for compound 3 lay 1.3-fold (0.12 log units) above the measured number; measured number inside the range.
By their numbers in this assay, from the lowest: compounds 3, 1 and 2 (each within the scatter of the next).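

Among the compounds shown here, compound 3 gave the first direct reading in this assay of hydrogen in place of methoxy on an aromatic carbon, at the place two atoms from the ring nitrogen, and the step is a 1.9-fold lower number from compound 2 to compound 3 (0.28 log units; within the scatter). The same replacement at a different aromatic carbon gives a 1.8-fold lower number from compound 1 to compound 3 (0.25 log units; within the scatter), so neither step separates the compounds, and the methoxy group at either place cannot be said to matter in this assay. No supporting measurement bears on this result, and the two steps offer no explanation for it.

As far as these compounds go, it remains open whether an ethoxy group, a fluorine atom or a longer chain at this carbon would give a number beyond the scatter of compound 2. The shared core also leaves open how a hydrogen at both of these carbons would read.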